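A few compounds are considered here, and "the series" means these few. Any claim that something is new, unique, unknown or untested is made for them only; others in the source may bear on it.

Measured in an ADME assay on microsomes from liver (Homo sapiens) for metabolic stability; on this read-out lower numbers stand for slow clearance and higher numbers for fast clearance:
- Compound 1 `CCCC(Oc1ccc(-n2cc(OC)cn2)cc1)c1ccc(C(=O)NCCC(=O)O)cc1`: < 8 mL/min/kg
- Compound 2 `O=C(O)CCNC(=O)c1ccc(C(Oc2ccc(-n3cc(C(F)(F)F)cn3)cc2)C2CC2)cc1`: < 8 mL/min/kg
- Compound 3 `CCCC(Oc1ccc(-n2cc(F)cn2)cc1)c1ccc(C(=O)NCCC(=O)O)cc1`: 12 mL/min/kg

Compound 2 gives < 8 mL/min/kg, which is a limit and not a number. That is the limit of < 8 mL/min/kg in this assay, at which 2 of the 3 values shown sit. Compound 1 gives < 8 mL/min/kg, also a limit.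

Compound 4 `CC(C)CC(Oc1ccc(-n2cc(C(F)(F)F)cn2)cc1)c1ccc(C(=O)NCCC(=O)O)cc1` has isobutyl in place of cyclopropyl on a saturated chain carbon bound to an aromatic carbon and an oxygen on an aromatic ring.

Within the data shown here, the only measured step is an at least 1.5-fold higher number from compound 1 to compound 3 (0.17 log units; that floor lies within the scatter), with fluoro in place of methoxy on an aromatic carbon. It does not touch the changed carbon, so it gives no size or direction for this change. Compound 3 also has an open chain on that carbon and gives 12 mL/min/kg.

The expected step is none beyond the scatter: a number no lower from compound 2 to compound 4 (the limit leaves the size open). The estimate for compound 4 is 8 mL/min/kg, with an expected range of 4 mL/min/kg to 16 mL/min/kg.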

Compound 4, clearance: 23 mL/min/kg
Estimate against measurement, compound 4: 2.9-fold (0.46 log units) below; the whole stated range lies below it.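

Isobutyl in place of cyclopropyl on this saturated chain carbon gives an at least 2.8-fold higher number from compound 2 to compound 4 (0.45 log units; beyond the scatter) in this assay and so shows, as the earlier compounds could not, that a change at this carbon can move clearance. On these data alone, the full size of the step stays unknown, as compound 2 gives a limit and not a number: the limit of < 8 mL/min/kg in this assay, at which 2 of the 4 values shown sit.

As far as these compounds go, whether a longer chain, a cyclobutyl ring or a chain bearing an amine on this carbon would read closer to compound 2 or to compound 4 remains open.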